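Methoxy to Bromo Swap and the Methoxyphenyl Carbonyl Position

The compounds below may be only part of what the source reports. "The series", "measured", "known", "first", "only" and "open" are said of these compounds alone.

Measured compounds:
compound 1, `COc1cccc(C(=O)n2c(-c3cn(C)c4ccc(OC)cc34)nc3ccccc32)c1`: 4600 nM
compound 2, `COc1ccc(C(=O)n2c(-c3cn(C)c4ccc(OC)cc34)nc3ccccc32)cc1`: 4900 nM
compound 3, `COc1cccc(C(=O)n2c(-c3cn(C)c4ccc(Br)cc34)nc3ccccc32)c1`: 10800 nM

Of the compounds shown here, three sharing one core have been tested in a functional assay on A549 cells (Homo sapiens) for inhibition, read by MTT assay, with a stated time of 24 h; a lower number here means a stronger inhibitor of growth, a higher number a weaker inhibitor of growth. Compound 1 has the structure `COc1cccc(C(=O)n2c(-c3cn(C)c4ccc(OC)cc34)nc3ccccc32)c1` and in this assay compound 1 gives 4600 nM. Compound 2 differs from it by 4-methoxyphenyl in place of 3-methoxyphenyl on a carbonyl carbon, and the step of a 1.1-fold higher number from compound 1 to compound 2 (0.03 log units; within the scatter). Compound 3 differs from compound 1 by bromo in place of methoxy on an aromatic carbon, and here the step of a 2.3-fold higher number from compound 1 to compound 3 (0.37 log units; beyond the scatter), leaving compound 3 with the highest number of the three.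

The unmeasured compound 4 has the structure `COc1ccc(C(=O)n2c(-c3cn(C)c4ccc(Br)cc34)nc3ccccc32)cc1`. It differs from compound 3 by 4-methoxyphenyl in place of 3-methoxyphenyl on a carbonyl carbon, which is the same change that separates compound 1 from compound 2, made on the same place. Among the compounds with values here, with the core of compound 3 the change has not yet been tried, so the only guide is the earlier pair, where the step stayed within the scatter. On that basis compound 4 is expected to sit close to compound 3, with an estimated step of a 1.0-fold higher number from compound 3 to compound 4 (0.01 log units; within the scatter). The estimate for compound 4 in this assay is 11000 nM, with a likely range from 5500 nM to 22000 nM.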

Compound 4, concentration for 50% growth inhibition: 11300 nM
Compound 4: middle estimate off by 1.0-fold (0.01 log units), on the low side, and the stated range covers the measured number.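

In this assay, putting 4-methoxyphenyl in place of 3-methoxyphenyl on the carbonyl carbon gave a 1.0-fold higher number from compound 3 to compound 4 (0.02 log units; within the scatter), and this small step matched the one seen earlier on the core of compound 1: the same change on two cores in this assay, a 1.1-fold higher number (0.03 log units; within the scatter) from compound 1 to compound 2 and a 1.0-fold higher number (0.02 log units; within the scatter) from compound 3 to compound 4, 1.0-fold (0.01 log units) apart, within the scatter of two such steps. Bromo in place of methoxy on the aromatic carbon gave a 2.3-fold higher number from compound 2 to compound 4 (0.36 log units; beyond the scatter), a modest step that also repeated when carried from one methoxyphenyl isomer to the other: the same change on two cores in this assay, a 2.3-fold higher number (0.37 log units; beyond the scatter) from compound 1 to compound 3 and a 2.3-fold higher number (0.36 log units; beyond the scatter) from compound 2 to compound 4, 1.0-fold (0.01 log units) apart, within the scatter of two such steps. Across these four compounds, each change therefore behaved the same way whichever form of the other place it was made on, with the bromo compounds giving the higher numbers, but this rests on only two pairs for each change and does not show that the agreement would extend to any other groups or cores.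

As far as these compounds go, whether the step seen here would hold for a chloro group, an amine or a carboxylic acid in place of the bromo, or for a hydroxy group or a longer chain in place of the methoxy on the phenyl ring, remains open. Also open, from the compounds shown here alone, is whether the same steps would appear outside this assay, in other cells or over other exposure times.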